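A few compounds are considered here, and "the series" means these few. Any claim that something is new, unique, unknown or untested is made for them only; others in the source may bear on it.

Compound 3, `CN(C)S(=O)(=O)Nc1ccc(C/N=C(\S)NCc2ccc(C(C)(C)C)cc2)cc1`, gives 14600 nM in a functional assay for antagonist activity at Vanilloid receptor (Rattus norvegicus); on this read-out lower numbers stand for stronger inhibition and higher numbers for weaker inhibition. Among the three compounds measured, compound 3 holds the highest number: compound 1, `CCCS(=O)(=O)Nc1ccc(C/N=C(\S)NCc2ccc(C(C)(C)C)cc2)cc1`, gives 4500 nM in this assay, and compound 2, `CNS(=O)(=O)Nc1ccc(C/N=C(\S)NCc2ccc(C(C)(C)C)cc2)cc1`, gives 2500 nM, so that the step runs a 3.2-fold higher number from compound 1 to compound 3 (0.51 log units; beyond the scatter) and a 5.8-fold higher number from compound 2 to compound 3 (0.77 log units; beyond the scatter), while the step of a 1.8-fold lower number from compound 1 to compound 2 (0.26 log units; within the scatter) stays within the scatter.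

Compound 4, `CN(c1ccc(C/N=C(\S)NCc2ccc(C(C)(C)C)cc2)cc1)S(C)(=O)=O`, differs from compound 3 in one place: methyl(methylsulfonyl)amino in place of (dimethylsulfamoyl)amino on an aromatic carbon. Among the measured compounds shown here, none of the measured steps repeats this change exactly. The closest is the step from compound 2 to compound 3, where a methyl entered on a sulfonamide nitrogen and the number rose by a 5.8-fold higher number from compound 2 to compound 3 (0.77 log units; beyond the scatter). In compound 4 a methyl again sits on a nitrogen, now the one bound to the aromatic carbon, and the group carries no hydrogen-bond donor at all, where compound 3 still has one. On this basis a further rise in this assay is expected rather than a fall, though of modest size, since only compound 3 and compound 2 speak to methylation of a nitrogen here.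

For compound 4 the expected step is a 1.4-fold higher number from compound 3 to compound 4 (0.14 log units; within the scatter), so compound 4 is estimated at 20000 nM, within a range from 6000 nM to 60000 nM.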

Compound 4, half-maximal inhibitory concentration: 2500 nM
Beside the measured number, compound 4's estimate is 8.0-fold (0.90 log units) above it, outside the stated range (below it).
By their numbers in this assay, from the lowest: compounds 2, 4 and 1 (each within the scatter of the next); then compound 3.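

On an aromatic carbon para to a large group, methyl(methylsulfonyl)amino in place of (dimethylsulfamoyl)amino brings a 5.8-fold lower number from compound 3 to compound 4 (0.77 log units; beyond the scatter) in this assay, which shows that a methyl on this nitrogen, in a group with 0 hydrogen-bond donors, is compatible with a number well under that of compound 3. Compound 4 instead sits within the scatter of the two compounds that keep the hydrogen-bond donor, with no change at the digits printed from compound 2 to compound 4 (within the scatter) and a 1.8-fold lower number from compound 1 to compound 4 (0.26 log units; within the scatter), so among these four compounds the loss of that donor does not go with a weaker read-out, and compound 3, with 1 donor, is the one that stands apart. No measurement bearing on the cause of this difference is available.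

The compounds shown do not separate the effect of the methyl on the nitrogen bound to the aromatic carbon from that of the group on the sulfonyl sulfur, and they do not show how the number would respond to hydrogen on that nitrogen with the methylsulfonyl kept. From the compounds shown here alone, it also remains open whether an ethyl on that nitrogen, or an acetyl in place of the methylsulfonyl, would hold the number near that of compound 4.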